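The source may report more compounds than this note shows. Statements on the series, on what has been measured and on what is new or still open speak of the compounds shown alone.

Compound 1, `CCOC(=O)c1ccc(-c2nn(CC)c3ccccc23)cc1`, gives > 10000 nM in a functional assay on cells (Platelet, Homo sapiens) for inhibition (a lower number here means a stronger inhibitor, a higher number a weaker inhibitor), and this is a limit of the assay rather than a number.
Compound 2, `CCCn1nc(-c2ccc(C(=O)OCC)cc2)c2ccccc21`, gives > 10000 nM in this assay, again a limit.
Compound 3, `CCNC(=O)c1ccc(-c2nn(Cc3ccccc3)c3ccccc23)cc1`, gives > 10000 nM in this assay, also a limit.

The change from compound 1 to compound 2 is methyl in place of hydrogen on a saturated chain carbon, two bonds along the chain from an aromatic nitrogen. The step that the two limits leave unreadable from compound 1 to compound 2 cannot be read, because of the limit of > 10000 nM in this assay, at which 3 of the 3 values shown sit. Compound 4, `CCCNC(=O)c1ccc(-c2nn(Cc3ccccc3)c3ccccc23)cc1`, is the compound still to be measured. It differs from compound 3 by methyl in place of hydrogen on a saturated chain carbon, two bonds along the chain from an amide-type nitrogen, the same kind of change as before, but here the carbon sits two bonds along the chain from an amide-type nitrogen rather than from an aromatic nitrogen. The difference between the cores of compound 1 and compound 3 is not broken down here. An expected step that the limit leaves unreadable from compound 3 to compound 4 rests on the limit of > 10000 nM in this assay, at which 3 of the 3 values shown sit, alone. Compound 4 is therefore estimated at 20000 nM, likely between 8000 nM and 60000 nM, most probably reported only as a limit.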

Compound 4, half-maximal inhibitory concentration: > 10000 nM
Compound 4: only a limit was reported (the forecaster's own chance of this, stated with the estimate: 85%); the middle value is on the limit's open side.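

The step from compound 3 to compound 4 cannot be read, because both values are limits of the assay: the limit of > 10000 nM in this assay, at which 4 of the 4 values shown sit.

The compounds shown give no actual number in this assay, so whether any of these changes alters inhibition stays open.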